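Solubility step from compound 3 to compound 4

The compounds below may be only part of what the source reports. "The series", "measured", "known", "first", "only" and "open" are said of these compounds alone.

In a physicochemical assay for solubility, read by LC-MS, in phosphate buffer, with a stated time of 24 h, at pH 7.4 (on this read-out lower numbers stand for lower solubility and higher numbers for higher solubility), compound 1 (`Cn1nccc1-c1cnc(NCc2c(F)ccc3c2CCO3)c2cn[nH]c(=O)c12`) gives 2000 nM, compound 2 (`CN(C)C(=O)c1cc(-c2cnc(NCc3c(F)ccc4c3CCO4)c3cn[nH]c(=O)c23)n(C)n1`) gives 3000 nM and compound 3 (`CNC(=O)c1cc(-c2cnc(NCc3c(F)ccc4c3CCO4)c3cn[nH]c(=O)c23)n(C)n1`) gives 7000 nM, the highest of the three numbers.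

The next structure is compound 4 (`Cc1nn(C)cc1-c1cnc(NCc2c(F)ccc3c2CCO3)c2cn[nH]c(=O)c12`), which has 1,3-dimethyl-1H-pyrazol-4-yl in place of the 1-methyl-3-(methylcarbamoyl)-1H-pyrazol-5-yl of compound 3, on an aromatic carbon of the shared core: 1,3-dimethyl-1H-pyrazol-4-yl in place of 1-methyl-3-(methylcarbamoyl)-1H-pyrazol-5-yl on an aromatic carbon.

For the measured compounds named here, three measured steps bear on this change. Methylcarbamoyl in place of hydrogen gave a 3.5-fold higher number from compound 1 to compound 3 (0.54 log units; beyond the scatter). Dimethylcarbamoyl in place of hydrogen gave a 1.5-fold higher number from compound 1 to compound 2 (0.18 log units; within the scatter). Hydrogen in place of methyl on the amide nitrogen gave a 2.3-fold higher number from compound 2 to compound 3 (0.37 log units; beyond the scatter).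

Compound 4 carries no carbamoyl group, and neither does compound 1, which makes compound 1 at 2000 nM the closest reference. A fall in this assay is therefore expected, of about the size of the first step read in reverse. The expected step is a 3.5-fold lower number from compound 3 to compound 4 (0.54 log units; beyond the scatter). No measured compound carries the 1,3-dimethyl-1H-pyrazol-4-yl group, and the range is kept wide for that reason. For compound 4 the estimated value is 2000 nM, with an expected range of 700 nM to 6000 nM.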

Compound 4, solubility: 9000 nM
Estimate against measurement, compound 4: 4.5-fold (0.65 log units) below; the whole stated range lies below it.
By their numbers in this assay, from the lowest: compounds 1 and 2 (each within the scatter of the next); then compounds 3 and 4 (each within the scatter of the next).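

In this assay, the carbamoyl group proves unnecessary for a number in the top group of this set: 1,3-dimethyl-1H-pyrazol-4-yl in place of 1-methyl-3-(methylcarbamoyl)-1H-pyrazol-5-yl gives a 1.3-fold higher number from compound 3 to compound 4 (0.11 log units; within the scatter), and in place of 3-(dimethylcarbamoyl)-1-methyl-1H-pyrazol-5-yl it gives a 3.0-fold higher number from compound 2 to compound 4 (0.48 log units; beyond the scatter), so a pyrazole with no carbonyl and no donor stands level with the secondary amide. The earlier steps shown here had only compared carbamoyl-bearing groups with 1-methyl-1H-pyrazol-5-yl, whereas the step between the two groups without a carbamoyl, a 4.5-fold higher number from compound 1 to compound 4 (0.65 log units; beyond the scatter), shows that the pyrazole itself matters at this place on the core. No measurement shown accounts for any of these steps.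

The 1,3-dimethyl-1H-pyrazol-4-yl group differs from 1-methyl-1H-pyrazol-5-yl in both its extra methyl and its point of attachment, and the compounds shown do not separate the two. Also open, going by these compounds, is how a 1-methyl-1H-pyrazol-4-yl group would read at this place, and how the 1,3-dimethyl-1H-pyrazol-4-yl group would read with an amine or a carboxylic acid in place of its 3-methyl.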